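Second fluorine on the carbamate aryl: series notes

This account rests on a few compounds, and the source may have more. Where it says the series, first, only, none or still open, it means among the compounds named here.

Measured so far in a functional assay on PANC-1 cells (Homo sapiens) for inhibition, read by MTT assay, with a stated time of 24 h, tested at 10 uM; a lower number here means less inhibition, a higher number more inhibition at the concentration tested (going by the name of the read-out):
compound 1 `CC(C)=CCC1Cc2c(OC(=O)Nc3cccc(F)c3)cc(=O)n(CCCO)c2CC1(C)C`: 66.1%
compound 2 `CC(C)=CCC1Cc2c(OC(=O)Nc3ccc(F)c(F)c3)cc(=O)n(CCCO)c2CC1(C)C`: 76.7%
compound 3 `CC(C)=CCC/C(C)=C/CC1Cc2c(OC(=O)Nc3ccccc3F)cc(=O)n(CCCO)c2CC1(C)C`: 71.6%

Compound 1 and compound 2 share one core and differ in one place, (fluoro in place of hydrogen on an aromatic carbon). That change gives a number 10.6 percentage points higher from compound 1 to compound 2 (beyond the scatter). Compound 3 carries a different core; the difference between the two cores is not broken down here. In this assay the number for compound 3 lies within the scatter of both compound 1 and compound 2, so no order among the three can be read from it.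

Compound 4 `CC(C)=CCC/C(C)=C/CC1Cc2c(OC(=O)Nc3ccc(F)cc3F)cc(=O)n(CCCO)c2CC1(C)C` is not yet measured. It differs from compound 3 in one place, (fluoro in place of hydrogen on an aromatic carbon). This is the same kind of change as from compound 1 to compound 2, but not the same: in compound 2 the entering fluoro sits ortho to a fluoro group, in compound 4 it sits meta to a fluoro group, while in both it sits para to a large group. The change has been seen once among the measured compounds, on the core of compound 1 only.

Going by that one step, the expectation is that compound 4 in this assay gains roughly as much as a number 10.6 percentage points higher from compound 1 to compound 2 (beyond the scatter) showed, and the estimated step is a number 7.4 percentage points higher from compound 3 to compound 4 (within the scatter). For compound 4 the expected number is 79%. For the measured compounds named here, the likely range for compound 4 runs from 67% to 90%, wide because the only precedent is a number 10.6 percentage points higher from compound 1 to compound 2 (beyond the scatter) on another core.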

Compound 4, a percentage reported as inhibition, at one concentration (the size of the read-out at that concentration, not a potency): 33.7%
Compound 4: the middle estimate sits 45.3 percentage points above what was measured; measured number below the stated range.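

In this assay, fluoro in place of hydrogen on the aromatic ring gives a number 37.9 percentage points lower from compound 3 to compound 4 (beyond the scatter), so the step does not carry over in direction from one core to the other: the same change on two cores in this assay, a number 10.6 percentage points higher (beyond the scatter) from compound 1 to compound 2 and a number 37.9 percentage points lower (beyond the scatter) from compound 3 to compound 4, 48.5 percentage points apart, beyond the scatter of two such steps

For this series, a gain from this kind of change on the core of compound 1 therefore gives no safe forecast for the core of compound 3, and each core needs its own reading. For the compounds shown here, the data do not show whether the core or the place of the entering fluoro sets the difference, as that fluoro stands meta to a fluoro group in compound 4 but not in compound 2, and the two steps differ in both respects at once, with only one step seen for each.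

Open, as far as these compounds go, is how a (2,4-difluorophenyl)carbamoyl group would read on the core of compound 1, and how the aryl group of compound 2 would read on the core of compound 3, the two pairings that would separate core from place. Also open, from the compounds shown here alone, is whether the loss belongs to fluoro alone, or whether a chloro, a methyl or a methoxy group at that same place on the 2-fluorophenyl group would read the same way.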